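Working notes: from compound 3 to compound 4

The source may report more compounds than this note shows. Statements on the series, on what has been measured and on what is new or still open speak of the compounds shown alone.

Measured in a functional assay on SMMC-7721 cells (Homo sapiens) for cytotoxicity, read by MTT assay, with a stated time of 24 h; on this read-out lower numbers stand for stronger inhibition and higher numbers for weaker inhibition
compound 1 `O=C1/C(=C/c2ccccc2F)CN(S(=O)(=O)c2ccc(F)cc2)C/C1=C\c1ccccc1F` gives 8370 nM
compound 2 `O=C1/C(=C/c2cccc([N+](=O)[O-])c2)CN(S(=O)(=O)c2ccc(F)cc2)C/C1=C\c1ccccc1F` gives 7820 nM
compound 3 `N#Cc1ccc(/C=C2\CN(S(=O)(=O)c3ccc(F)cc3)C/C(=C\c3ccccc3F)C2=O)cc1` gives 10300 nM

The three measured compounds cannot be separated. With a 1.2-fold higher number from compound 1 to compound 3 (0.09 log units; within the scatter) and a 1.3-fold higher number from compound 2 to compound 3 (0.12 log units; within the scatter) both within the scatter, compound 3 stands level with compound 1 and compound 2.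

Compound 4 `COc1cc(/C=C2\CN(S(=O)(=O)c3ccc(F)cc3)C/C(=C\c3ccccc3F)C2=O)cc(OC)c1OC` carries 3,4,5-trimethoxyphenyl in place of 4-cyanophenyl on a double-bonded chain carbon bound to a double-bonded ring carbon and is otherwise unchanged.

Three measured exchanges at this same place bear on the change: a 1.1-fold lower number from compound 1 to compound 2 (0.03 log units; within the scatter) and a 1.2-fold higher number from compound 1 to compound 3 (0.09 log units; within the scatter) and a 1.3-fold higher number from compound 2 to compound 3 (0.12 log units; within the scatter) all stayed within the scatter. For the measured compounds named here, no measured compound carries 3,4,5-trimethoxyphenyl, so the entering group has no direct test here. In this assay no step beyond the scatter is therefore expected, and no direction is favoured.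

The estimated step is a 1.2-fold lower number from compound 3 to compound 4 (0.08 log units; within the scatter) and remains an expectation only.

Compound 4 is expected at 8500 nM (estimated range 4500 nM to 16000 nM).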

Compound 4, half-maximal inhibitory concentration: 6340 nM
Compound 4: the middle estimate sits 1.3-fold (0.13 log units) above what was measured; low and high end bracket the measured number.
By their numbers in this assay, from the lowest: compounds 4, 2, 1 and 3 (each within the scatter of the next).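

In this assay, 3,4,5-trimethoxyphenyl now gives this position a direct test, and the new group stays level with all three earlier groups: the steps of a 1.6-fold lower number from compound 3 to compound 4 (0.21 log units; within the scatter) and a 1.2-fold lower number from compound 2 to compound 4 (0.09 log units; within the scatter) and a 1.3-fold lower number from compound 1 to compound 4 (0.12 log units; within the scatter) all remain within the scatter. Among compounds 1 to 4, the exchange at this place therefore extends to a group with more heavy atoms and more hydrogen-bond acceptors than 4-cyanophenyl, and still yields no separable difference. No supporting data are available to account for this level behaviour.

Going by these compounds, whether an amine or a carboxylic acid on the phenyl ring, or a longer chain in place of that ring, would produce a step beyond the scatter remains open. On these data alone, whether the same level behaviour holds in any other cell line also remains open.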